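The source may report more compounds than this note shows. Statements on the series, on what has been measured and on what is new or still open speak of the compounds shown alone.

Three ureas built on one shared core have been measured. Going by the values given here, compound 1 `Cc1ccc(NC(=O)Nc2cccc(CNc3nccnc3Cl)c2)cc1Cl` gives 17500 nM in a functional assay on MGC-803 cells (Homo sapiens) for antiproliferative activity, read by MTT assay, with a stated time of 48 h (a lower number here means a stronger inhibitor, a higher number a weaker inhibitor), and compound 3 `COc1ccccc1NC(=O)Nc1cccc(CNc2nccnc2Cl)c1` gives 12200 nM in this assay; the step of a 1.4-fold lower number from compound 1 to compound 3 (0.16 log units; within the scatter) is the only single-change step among them. Compound 2 `CC(C)(C)c1ccc(NC(=O)Nc2cccc(CNc3nccnc3Cl)c2)cc1` gives 4820 nM in this assay, the lowest of the three numbers and beyond the scatter from both others. Compound 4 `CS(=O)(=O)c1ccc(NC(=O)Nc2cccc(CNc3nccnc3Cl)c2)cc1` differs from compound 2 by methylsulfonyl in place of tert-butyl on an aromatic carbon. Among the compounds with values here, no measured step covers such an exchange, and the one step measured, a 1.4-fold lower number from compound 1 to compound 3 (0.16 log units; within the scatter), lies within the scatter, while compound 2 against compounds 1 and 3 shows that groups on this ring can shift the number beyond it. Compound 4 is therefore expected to give roughly 10000 nM, between 3000 nM and 35000 nM. The expected step is a 2.1-fold higher number from compound 2 to compound 4 (0.32 log units; beyond the scatter).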

Compound 4, half-maximal inhibitory concentration: 12300 nM
Compound 4: middle estimate off by 1.2-fold (0.09 log units), on the low side; the measured number falls inside the stated range.
By their numbers in this assay, from the lowest: compound 2; then compounds 3, 4 and 1 (each within the scatter of the next).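

In this assay the exchange of tert-butyl for methylsulfonyl, para to a large group, gives a 2.6-fold higher number from compound 2 to compound 4 (0.41 log units; beyond the scatter) and so shows a single change at this position moving the number beyond the scatter. The two groups have the same heavy-atom count, so that count alone does not fix the number here, and compound 2 keeps the lowest number of the four. As far as these compounds go, whether an amine or a carboxylic acid on this carbon would come nearer to compound 2 or to compound 4 stays open. Nothing shown bears on the reason for this step.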